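The source may report more compounds than this note shows. Statements on the series, on what has been measured and on what is new or still open speak of the compounds shown alone.

Three compounds share one core and differ only in the aromatic group attached to a carbon with a double bond to nitrogen. Compound 1 `O=C(CSc1nnc(-c2ccncc2)o1)N/N=C/c1ccccc1` gives 17300 nM in a functional assay on HepG2 cells (Homo sapiens) for cytotoxicity, read by MTT assay, with a stated time of 48 h; on this read-out higher numbers stand for weaker inhibition and lower numbers for stronger inhibition. Compound 2 `O=C(CSc1nnc(-c2ccncc2)o1)N/N=C/c1ccc(Cl)cc1` gives 15700 nM in this assay, and compound 3 `O=C(CSc1nnc(-c2ccncc2)o1)N/N=C/c1ccccc1F` gives 16000 nM in this assay. Compound 3 sits amid three numbers that are all within the scatter of one another: a 1.1-fold lower number from compound 1 to compound 2 (0.04 log units; within the scatter), a 1.1-fold lower number from compound 1 to compound 3 (0.03 log units; within the scatter) and a 1.0-fold higher number from compound 2 to compound 3 (0.01 log units; within the scatter). Compound 4 `O=C(CSc1nnc(-c2ccncc2)o1)N/N=C/c1cc(Cl)cc(Cl)c1O` is not yet measured; its change from compound 3 is 3,5-dichloro-2-hydroxyphenyl in place of 2-fluorophenyl on a carbon with a double bond to nitrogen. Those earlier ring changes, a 1.1-fold lower number from compound 1 to compound 2 (0.04 log units; within the scatter) and a 1.1-fold lower number from compound 1 to compound 3 (0.03 log units; within the scatter), stayed within the scatter, so no step beyond the scatter is expected in this assay. Compound 4 is therefore expected to give about 13000 nM, between 4000 nM and 40000 nM. That amounts to an expected 1.2-fold lower number from compound 3 to compound 4 (0.09 log units; within the scatter).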

Compound 4, half-maximal inhibitory concentration: 3260 nM
Estimate against measurement, compound 4: 4.0-fold (0.60 log units) above; measured number outside the range, below it.
By their numbers in this assay, from the lowest: compound 4; then compounds 2, 3 and 1 (each within the scatter of the next).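

In this assay, the aromatic group on the carbon with a double bond to nitrogen can shift the number beyond the scatter after all: 3,5-dichloro-2-hydroxyphenyl gives a 4.9-fold lower number from compound 3 to compound 4 (0.69 log units; beyond the scatter), with a 4.8-fold lower number from compound 2 to compound 4 (0.68 log units; beyond the scatter) and a 5.3-fold lower number from compound 1 to compound 4 (0.72 log units; beyond the scatter). Unlike 2-fluorophenyl, this group carries a hydrogen-bond donor and a hydrogen-bond acceptor, but that alone does not explain the drop. Nothing available here accounts for the step. On these data alone, the hydroxy and the two chloro groups enter together, so their separate shares remain open. As far as these compounds go, how an amine or a carboxylic acid on this ring would read out also remains open.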